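Swapping Thiophene for Phenyl on Two Related Cores

A few compounds are considered here, and "the series" means these few. Any claim that something is new, unique, unknown or untested is made for them only; others in the source may bear on it.

Of the compounds shown here, three have so far been tested in a functional assay on HeLa S3 cells (Homo sapiens) for antiproliferative activity, read by XTT assay, with a stated time of 72 h; on this read-out higher numbers stand for weaker inhibition and lower numbers for stronger inhibition. Compound 1 `Cc1nc(N)c2c(-c3ccccc3)cn([C@@H]3O[C@H](CO)[C@@H](O)[C@H]3O)c2n1` gives in this assay only a limit of the assay, not a number, namely > 20000 nM. Compound 2 `Cc1nc(N)c2c(-c3cccs3)cn([C@@H]3O[C@H](CO)[C@@H](O)[C@H]3O)c2n1` likewise gives in this assay a limit rather than a number, > 20000 nM. Compound 3 `COc1ncnc2c1c(-c1cccs1)cn2[C@@H]1O[C@H](CO)[C@@H](O)[C@H]1O` is built on a different core; how the core of compound 3 differs from the core of compound 2 is not broken down here. In this assay, among the compounds with values here, compound 3 gives 1760 nM, the only number among the three values.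

Compound 1 and compound 2 differ in one place: phenyl in place of thiophen-2-yl on an aromatic carbon. From the compounds shown here alone, because both of their values sit at the limit of > 20000 nM in this assay, at which 2 of the 3 values shown sit, the step that the two limits leave unreadable from compound 2 to compound 1 cannot be read, so its size stays unknown.

Compound 4 `COc1ncnc2c1c(-c1ccccc1)cn2[C@@H]1O[C@H](CO)[C@@H](O)[C@H]1O` has not yet been measured. It stands to compound 3 exactly as compound 1 stands to compound 2: phenyl in place of thiophen-2-yl on an aromatic carbon. The place of the change is the same word for word, so this is the same change made on a second core.

Since the earlier step gave no readable size, the expectation for compound 4 rests on the value of compound 3, 1760 nM, as the anchor. The step of a 1.4-fold higher number from compound 3 to compound 4 (0.15 log units; within the scatter) is expected to be small, within the usual scatter. Compound 4 is therefore estimated at about 2500 nM in this assay, with an expected range from 800 nM to 9000 nM.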

Compound 4, half-maximal inhibitory concentration: > 20000 nM
Compound 4: a limit, no number; the forecaster's own chance of this, stated with the estimate: 10%; at least 8.0-fold (0.90 log units) between middle value and limit.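

On the core of compound 3, phenyl in place of thiophen-2-yl gives in this assay an at least 11-fold higher number from compound 3 to compound 4 (1.05 log units; beyond the scatter), a large step beyond the scatter, and compound 3 at 1760 nM is the only compound shown with a number. Compound 4 gives > 20000 nM, which is a limit of the assay and not a number, so the step has a lower bound but no exact size. The same change on the other core cannot be read, and so the series shows a clear loss on one core only; it neither confirms nor contradicts that the change behaves alike on both cores, with the values of compound 1, compound 2 and compound 4 all resting on the same limit: the limit of > 20000 nM in this assay, at which 3 of the 4 values shown sit.

From the compounds shown here alone, what stays open is whether the number seen for compound 3 depends on thiophen-2-yl specifically or would survive with another group at the same place, such as an amine, a carboxylic acid or a longer chain. Going by these compounds, it is also open how far beyond the limit compound 1, compound 2 and compound 4 lie, and so whether the two cores differ at all in their response to this change.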